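Aryl swap on the shared core: outlook for compound 4

The source may report more compounds than this note shows. Statements on the series, on what has been measured and on what is new or still open speak of the compounds shown alone.

The shared core is seen in compound 1 `COc1nc(C(C)(C)C)ccc1[C@@H](c1ccccc1)[C@@](O)(CCN(C)C)c1cccc2ccccc12`, which in a toxicity assay on Vero cells (Chlorocebus sabaeus) for cytotoxicity (on this read-out higher numbers stand for lower toxicity in this test and lower numbers for higher toxicity in this test), gives 27.6 ug/mL. Compound 3 `COc1nc(C2CCCCC2)ccc1[C@@H](c1ccccc1)[C@@](O)(CCN(C)C)c1cccc2ccccc12` gives 32.3 ug/mL in this assay. Compound 2 `COc1nc(-c2cccc(Cl)c2)ccc1[C@@H](c1ccccc1)[C@@](O)(CCN(C)C)c1cccc2ccccc12` is reported in this assay only as a limit of the assay, > 50 ug/mL, not as a number (the limit of > 50 ug/mL in this assay, at which 1 of the 3 values shown sits). The steps of an at least 1.8-fold higher number from compound 1 to compound 2 (0.25 log units; that floor lies within the scatter) and an at least 1.5-fold lower number from compound 2 to compound 3 (0.18 log units; that floor lies within the scatter) are the two that touch compound 2, and both are floors lying within the scatter. Compound 4 `COc1nc(-c2ccc(F)cc2)ccc1[C@@H](c1ccccc1)[C@@](O)(CCN(C)C)c1cccc2ccccc12` differs from compound 2 by 4-fluorophenyl in place of 3-chlorophenyl on an aromatic carbon. Among the measured compounds shown here, no measured step exchanges one aryl group for another, so the expected change a number no higher from compound 2 to compound 4 (the limit leaves the size open) in this assay is none beyond the scatter. Compound 4 is therefore expected to give about 50 ug/mL, within 28 ug/mL to 100 ug/mL, quite possibly again as a limit.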

Compound 4, half-maximal cytotoxic concentration: > 50 ug/mL
Compound 4: only a limit was reported; the forecaster's own chance of this, stated with the estimate: 55%; the middle value lies on the limit itself.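

Compound 4 is reported in this assay only as a limit of the assay, > 50 ug/mL. A second aryl group on this aromatic carbon next to the ring nitrogen thus also ends at the limit, with chlorine and fluorine and their ring positions both changed, and the step between compound 2 and compound 4 cannot be read: the limit of > 50 ug/mL in this assay, at which 2 of the 4 values shown sit. The steps of an at least 1.5-fold higher number from compound 3 to compound 4 (0.18 log units; that floor lies within the scatter) and an at least 1.8-fold higher number from compound 1 to compound 4 (0.25 log units; that floor lies within the scatter) give only floors.

Going by these compounds, whether the aryl groups truly differ from tert-butyl or cyclohexyl here stays open. Also open, on these data alone, is how a phenyl ring bearing an amine or a carboxylic acid would read in this assay.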